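The compounds below may be only part of what the source reports. "The series", "measured", "known", "first", "only" and "open" are said of these compounds alone.

Measured so far:
- compound 1, `Cc1cc(C)c(-c2nc(CN3CCC(C(=O)NCCCN4C[C@H](C)C[C@H](C)C4)CC3)c(C)o2)c(C)c1`: 6570 nM
- compound 2, `Cc1ccccc1-c1nc(CN2CCC(C(=O)NCCCN3CCC(C)CC3)CC2)c(C)o1`: 12300 nM

In an ADME assay on Huh7.5.1 cells (Homo sapiens) for cytotoxicity, read by ATP content, with a stated time of 48 h (a higher number here means that more compound is tolerated, a lower number that less compound is tolerated), compound 2 gives 12300 nM, the highest of the two numbers in hand. The nearest is compound 1, which in this assay gives 6570 nM; the gap between the two lies within the scatter, so nothing can be said of an order between them.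

Compound 3, `Cc1ccccc1-c1nc(CN2CCC(C(=O)NCCCCN3C[C@H](C)C[C@H](C)C3)CC2)c(C)o1`, is not yet measured in this assay. It differs from compound 2 in one place: (3,5-dimethylpiperidin-1-yl)methyl in place of 4-methylpiperidin-1-yl on a saturated chain carbon, three bonds along the chain from an amide-type nitrogen. Among the compounds with values here, no step between two measured compounds is recorded, so the expected size of this step rests on the two values alone. Compound 1, which carries the 3,5-dimethylpiperidin-1-yl group on a chain of the shorter kind with a different aryl group, sits within the scatter of compound 2, so no step beyond the scatter is expected from compound 2 to compound 3, in either direction; a small drift to a lower number is the most that seems likely.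

The estimate for compound 3 in this assay is 9000 nM, with a range from 4000 nM to 20000 nM, which is expected to amount to a 1.4-fold lower number from compound 2 to compound 3 (0.14 log units; within the scatter).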

Compound 3, half-maximal cytotoxic concentration: 23100 nM
Compound 3: middle estimate off by 2.6-fold (0.41 log units), on the low side; measured number above the stated range.
By their numbers in this assay, from the lowest: compounds 1, 2 and 3 (each within the scatter of the next, the first and the last beyond it).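

In this assay, within the data shown here, the first pair that differs in one place gives a 1.9-fold higher number from compound 2 to compound 3 (0.27 log units; within the scatter), for (3,5-dimethylpiperidin-1-yl)methyl in place of 4-methylpiperidin-1-yl on a saturated chain carbon, three bonds along the chain from an amide-type nitrogen. This position therefore takes a group of 9 heavy atoms with 2 defined stereocentres in place of one of 7 heavy atoms without a step beyond the scatter, and the change, also readable as 2-(4-methylpiperidin-1-yl)ethyl to 3-(3,5-dimethylpiperidin-1-yl)propyl, joins a longer chain and a different methyl pattern on the piperidine in a single step. No supporting measurement bears on why the step has this size.

The chain and the methyl pattern remain unseparated, and that would take the 3-(4-methylpiperidin-1-yl)propyl group or the 2-(3,5-dimethylpiperidin-1-yl)ethyl group on the core of compound 2. Also open, as far as these compounds go, is what a longer chain such as 4-(3,5-dimethylpiperidin-1-yl)butyl, or a morpholin-4-yl group at the chain end, would give at this position.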